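The compounds below may be only part of what the source reports. "The series", "measured", "known", "first", "only" and "open" are said of these compounds alone.

Working notes on the series.

Three compounds of this series have a number in a functional assay on a cell-free system (plasma) for agonist activity at thromboxane A2 receptor (Homo sapiens); a lower number here means a stronger inhibitor, a higher number a weaker inhibitor. Compound 1 `O=C(O)CCC/C=C1/C[C@H]2C[C@@H](O)[C@H](/C=N/NC(=O)Nc3ccccc3)[C@H]2C1` gives 100 nM. Compound 2 `O=C(O)COC/C=C1\C[C@H]2C[C@@H](O)[C@H](/C=N/NC(=O)Nc3ccccc3)[C@H]2C1` gives 6000 nM. Compound 3 `O=C(O)CCC/C=C1\C[C@H]2C[C@@H](O)[C@H](/C=N/NC(=O)Nc3ccc([N+](=O)[O-])cc3)[C@H]2C1` gives 60 nM, the lowest of the three numbers; its nearest neighbour is compound 1, whose number lies within the scatter of that of compound 3, so no order between compound 3 and compound 1 can be read from these two values, while compound 2 stands beyond the scatter with a far higher number.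

The step to compound 4 `O=C(O)CCC/C=C1\C[C@H]2C[C@@H](O)[C@H](/C=N/NC(=O)Nc3ccccc3)[C@H]2C1` changes one place: hydrogen in place of nitro on an aromatic carbon. Among the compounds with values here, no step between measured compounds covers this change, so its size can only be expected, not read off. With compound 3 at 60 nM and compound 1 at 100 nM both low, the expectation is a small step in this assay, at most a modest rise, that may well remain within the scatter. For compound 4 the estimated number in this assay is 100 nM, in the range from 40 nM to 300 nM, an estimated step of a 1.7-fold higher number from compound 3 to compound 4 (0.22 log units; within the scatter).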

Compound 4, half-maximal inhibitory concentration: 1700 nM
Compound 4: the middle estimate sits 17-fold (1.23 log units) below what was measured; the measured number lies above the stated range.
By their numbers in this assay, from the lowest: compounds 3 and 1 (each within the scatter of the next); then compound 4; then compound 2.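

With hydrogen in place of nitro on the aromatic carbon para to a large group, this assay gives a 28-fold higher number from compound 3 to compound 4 (1.45 log units; beyond the scatter), so in this series the group at this position can shift the number by a large step. The chain position gives a modest step, with 2-carboxyethyl in place of carboxymethoxy giving a 3.5-fold lower number from compound 2 to compound 4 (0.55 log units; beyond the scatter). The large step of a 17-fold higher number from compound 1 to compound 4 (1.23 log units; beyond the scatter) can only be assigned to the double bond, drawn Z in compound 1 and E in compound 4, because of this: the fact that compounds 1 and 4 differ only in the configuration as drawn

On these data alone, it remains open whether the nitro step holds with the double bond drawn as in compound 1, and whether chloro, methoxy or an amine at the same aromatic carbon would behave like nitro or like hydrogen. A longer chain ending in the carboxylic acid also remains an open comparison.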